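Ester to Amide on a Theophylline-Like Core: Cytotoxicity

A few compounds are considered here, and "the series" means these few. Any claim that something is new, unique, unknown or untested is made for them only; others in the source may bear on it.

Measured compounds:
- Compound 1 `C#CCOC(=O)Cn1cnc2c1c(=O)n(C)c(=O)n2C`: 156000 nM
- Compound 2 `CCn1c(=O)ccn(C2OC(Cn3cc(COC(=O)CNC(=O)Cn4cnc5c4c(=O)n(C)c(=O)n5C)nn3)C(OC)C2OC)c1=O`: 52000 nM

In a functional assay on A549 cells (Homo sapiens) for cytotoxicity, read by MTT assay, with a stated time of 48 h (on this read-out higher numbers stand for weaker inhibition and lower numbers for stronger inhibition), compound 1 gives 156000 nM, the highest of the two numbers shown. Within the data shown here, compound 2, the only other measured compound, gives 52000 nM, a number that lies beyond the scatter below compound 1; no single structural step links these two, so nothing more is drawn from the pair.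

Compound 3 `C#CCNC(=O)Cn1cnc2c1c(=O)n(C)c(=O)n2C` has not yet been measured. It differs from compound 1 in one place, (propargylamino in place of propargyloxy on a carbonyl carbon). Among the measured compounds shown here, with no measured step of this kind available, the size of the change from compound 1 to compound 3 cannot be read from the numbers; both compounds are weak in this assay, and the step of a 1.0-fold lower number from compound 1 to compound 3 (0.02 log units; within the scatter) is expected to stay within the scatter. Compound 3 is therefore estimated at 150000 nM, with a range from 60000 nM to 400000 nM.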

Compound 3, half-maximal inhibitory concentration: 114000 nM
Beside the measured number, compound 3's estimate is 1.3-fold (0.12 log units) above it; low and high end bracket the measured number.
By their numbers in this assay, from the lowest: compound 2; then compounds 3 and 1 (each within the scatter of the next).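

In this assay, propargylamino in place of propargyloxy on a carbonyl carbon gives a 1.4-fold lower number from compound 1 to compound 3 (0.14 log units; within the scatter), the first step measured at this position. This exchanges a group counted with one hydrogen-bond acceptor and no donor for one counted with one donor and no acceptor, and this single pair shows no separation between the two on this read-out. Nothing available here bears on this result, so it stays a bare observation.

The compounds shown leave open whether a different group on this carbonyl carbon, such as a free carboxylic acid, a simple methylamino or a longer chain like butynylamino, would move the number beyond the scatter. They also leave open what a methyl group on the amide nitrogen, or a saturated propylamino in place of propargylamino, would do.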